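The source may report more compounds than this note shows. Statements on the series, on what has been measured and on what is new or still open speak of the compounds shown alone.

Compound 3 `CN(C)CCn1cnnc1-c1cc(Oc2ccc(NC(=O)N/N=C/c3cccc(Cl)c3Cl)cc2F)ccn1` carries the lowest number of the three measured in a functional assay on HT-29 cells (Homo sapiens) for cytotoxicity, read by MTT assay, with a stated time of 72 h (a higher number here means a weaker inhibitor, a lower number a stronger inhibitor), at 130 nM. Compound 1 `CN(C)CCn1cnnc1-c1cc(Oc2ccc(NC(=O)N/N=C/c3cccc(Br)c3)cc2F)ccn1` gives 380 nM and compound 2 `CN(C)CCn1cnnc1-c1cc(Oc2ccc(NC(=O)N/N=C/c3ccc(F)cc3Cl)cc2F)ccn1` gives 510 nM; the steps to compound 3 are a 2.9-fold lower number from compound 1 to compound 3 (0.47 log units; beyond the scatter) and a 3.9-fold lower number from compound 2 to compound 3 (0.59 log units; beyond the scatter), while a 1.3-fold higher number from compound 1 to compound 2 (0.13 log units; within the scatter) lies within the scatter. Compound 4 `CN(C)CCn1cnnc1-c1cc(Oc2ccc(NC(=O)N/N=C/c3ccc(O)cc3)cc2F)ccn1` differs from compound 3 by 4-hydroxyphenyl in place of 2,3-dichlorophenyl on a carbon with a double bond to nitrogen. Among the compounds with values here, no measured step exchanges a halogen-bearing ring for a hydroxyl-bearing one, so the three steps bear on it only loosely; all three were modest at most. Since compound 3 holds the lowest number, the step is expected to run upward, modestly, as a 3.1-fold higher number from compound 3 to compound 4 (0.49 log units; beyond the scatter). Compound 4 is therefore estimated at 400 nM, with a range from 150 nM to 1200 nM.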

Compound 4, half-maximal inhibitory concentration: 1920 nM
Compound 4: the middle estimate sits 4.8-fold (0.68 log units) below what was measured, outside the stated range (above it).
By their numbers in this assay, from the lowest: compound 3; then compounds 1 and 2 (each within the scatter of the next); then compound 4.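

In this assay the group on a carbon with a double bond to nitrogen now shows a large step, as 4-hydroxyphenyl in place of 2,3-dichlorophenyl gives a 15-fold higher number from compound 3 to compound 4 (1.17 log units; beyond the scatter) and the halogen-bearing rings had differed only modestly. The other two steps run the same way, with a 5.1-fold higher number from compound 1 to compound 4 (0.70 log units; beyond the scatter) and a 3.8-fold higher number from compound 2 to compound 4 (0.58 log units; beyond the scatter) leaving compound 4, the only ring here without halogen, with the highest number of the four. No available data bear on the reason for this rise. On these data alone, whether it follows the gain of the hydroxyl or the loss of halogen stays open, and an unsubstituted phenyl or a methoxy group on the ring would separate the two.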